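The source may hold more compounds than are shown below. What is called first, only, known or untested is meant among the compounds shown, and "the series" means these compounds.

Measured compounds:
Compound 1, `C=COC(=O)[C@H](CCSC)NC(=O)c1ccc(CNCc2c[nH]cn2)cc1-c1ccccc1C`. In a functional assay on NIH3T3 cells (Mus musculus) (on this read-out lower numbers stand for an effect already at smaller amounts and higher numbers for an effect only at larger amounts of compound), compound 1 gives > 10 uM, a limit of the assay.
Compound 2, `CCCCC(CC)OC(=O)[C@H](CCSC)NC(=O)c1ccc(CNCc2c[nH]cn2)cc1-c1ccccc1C`. In this assay compound 2 gives > 10 uM, likewise a limit of the assay.

Compound 2 stands only at a limit; both values shown sit at the limit of > 10 uM in this assay, at which 2 of the 2 values shown sit. The step from compound 1 to compound 2, a step that the two limits leave unreadable from compound 1 to compound 2, has both ends at a limit and gives no readable size.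

Compound 3, `CSCC[C@H](NC(=O)c1ccc(CNCc2c[nH]cn2)cc1-c1ccccc1C)C(=O)OC1CCCCC1`, is not yet measured in this assay. It differs from compound 2 by cyclohexyl in place of 1-ethylpentyl on an oxygen next to a carbonyl group. Within the data shown here, the only measured step concerns the same oxygen next to a carbonyl group, but its size is unreadable; no other step bears on the change, so no direction can be derived from the measured pairs.

Given that compound 2 gives only > 10 uM, a limit, nothing beyond the scatter is expected for compound 3 in this assay, and the most likely outcome is again a value at the limit. Compound 3 is estimated at 20 uM, with a range from 5 uM to 80 uM. The estimated step that the limit leaves unreadable from compound 2 to compound 3 is expected to lie within the scatter.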

Compound 3, concentration for half-maximal effect: > 10 uM
Compound 3 gave a limit, no number (the forecaster's own chance of this, stated with the estimate: 80%); the middle value lies beyond the limit too.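

Compound 1, compound 2 and compound 3 all stand only at a limit in this assay, so no step among them can be read: the limit of > 10 uM in this assay, at which 3 of the 3 values shown sit.

The compounds shown leave open whether any group on the oxygen next to a carbonyl group gives a readable value in this assay, and how vinyl, 1-ethylpentyl and cyclohexyl compare there.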